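Isoxazole substituent removed: phenyl to hydrogen in compound 4

The source may hold more compounds than are shown below. What is called first, only, known or untested is meant among the compounds shown, and "the series" means these compounds.

Measured in an assay on TT cells for inhibition of proto-oncogene tyrosine-protein kinase receptor Ret variant C634W (Homo sapiens), read by MTT assay, with a stated time of 10 days; on this read-out higher numbers stand for weaker inhibition of growth and lower numbers for stronger inhibition of growth:
compound 1 `Nc1ncnc2c1c(-c1cc(C3CC3)on1)nn2C1CCCCC1` gives 290 nM
compound 3 `CC(C)(O)Cn1nc(-c2cc(C3CC3)on2)c2c(N)ncnc21` gives 4250 nM
compound 2 `CC(C)n1nc(-c2cc(-c3ccccc3)on2)c2c(N)ncnc21` gives only a limit, > 10000 nM

For the measured compounds named here, the single step between measured compounds is a 15-fold higher number from compound 1 to compound 3 (1.17 log units; beyond the scatter); it changes the group on the aromatic nitrogen and leaves the five-membered ring untouched. Going by the values given here, compound 2 stands at the limit of the assay, (the limit of > 10000 nM in this assay, at which 1 of the 3 values shown sits), so no number is known for it and no step from it can be sized. Compound 4 `CC(C)n1nc(-c2ccon2)c2c(N)ncnc21` differs from compound 2 in one place: hydrogen in place of phenyl on an aromatic carbon. Among the compounds with values here, no measured step bears on this change, since the one step recorded concerns the group on the aromatic nitrogen and not the five-membered ring. Compounds 1 and 3 carry no phenyl and both give numbers, whereas compound 2 carries phenyl and gives none. On that basis alone, a number rather than a limit seems the likelier outcome, but the size of any shift is open. Compound 4 is expected at 3000 nM, with a range from 600 nM to 15000 nM. The step this estimate implies is an at least 3.3-fold lower number from compound 2 to compound 4 (0.52 log units; beyond the scatter), an expectation and not a measurement.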

Compound 4, concentration for 50% growth inhibition: 7920 nM
Compound 4: the middle estimate sits 2.6-fold (0.42 log units) below what was measured; the measured number falls inside the stated range.
By their numbers in this assay, from the lowest: compound 1; then compounds 3 and 4 (each within the scatter of the next). At a limit, above all of these: compound 2.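

In this assay, for the compounds shown here, compound 4 gives 7920 nM as a measured number, so with hydrogen on this aromatic carbon, next to the ring oxygen, the series has a real value at this position for the first time with this nitrogen group. Compound 2, with phenyl on the same carbon, gives > 10000 nM as a limit and not a number. Going by these compounds, the change of phenyl to hydrogen therefore reads only as an at least 1.2-fold lower number from compound 2 to compound 4 (0.10 log units; that floor lies within the scatter) and is bounded from one side, so its true size stays unknown: the limit of > 10000 nM in this assay, at which 1 of the 4 values shown sits.

On these data alone, how cyclopropyl on this carbon compares with hydrogen, with the nitrogen group of compound 4 held fixed, stays open. Also open, as far as these compounds go, is whether an amine or a carboxylic acid on this carbon would move the number beyond the scatter from compound 4.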